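Compound 1 to compound 4: amino replaces the acetylpiperazine

The compounds below may be only part of what the source reports. "The series", "measured", "known", "first", "only" and "open" are said of these compounds alone.

In a functional assay on NCI-H1581 cells (Homo sapiens) for antiproliferative activity, read by CCK-8 assay, with a stated time of 72 h (on this read-out lower numbers stand for stronger inhibition and higher numbers for weaker inhibition), compound 1 (`COc1cc(OC)c(Cl)c(-c2ccc3c(NC(=O)c4ccc(N5CCN(C(C)=O)CC5)cc4)n[nH]c3n2)c1Cl`) gives 43.3 nM as the second highest of three values, with compound 3 (`COc1cc(C(=O)Nc2n[nH]c3nc(-c4c(Cl)c(OC)cc(OC)c4Cl)ccc23)ccc1N1CCN(C)CC1`) lower at 15.6 nM and compound 2 (`COc1cc(OC)c(Cl)c(-c2ccc3c(NC(=O)c4ccc(N5CCN(C)CC5)c(Cl)c4)n[nH]c3n2)c1Cl`) higher at 191 nM in the same read-out. Compound 4 (`COc1cc(OC)c(Cl)c(-c2ccc3c(NC(=O)c4ccc(N)cc4)n[nH]c3n2)c1Cl`) carries amino in place of 4-acetylpiperazin-1-yl on an aromatic carbon. For the measured compounds named here, the only measured single-place step is a 12-fold lower number from compound 2 to compound 3 (1.09 log units; beyond the scatter) and it is large, but it lies at another place, and no measured step touches the group that leaves. Given how much of that group is lost, a moderate move to a higher number in this assay is expected, estimated as a 3.5-fold higher number from compound 1 to compound 4 (0.54 log units; beyond the scatter) with wide uncertainty. The estimated value for compound 4 is 150 nM with an expected range from 40 nM to 600 nM on this evidence.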

Compound 4, half-maximal inhibitory concentration: 218 nM
Estimate against measurement, compound 4: 1.5-fold (0.16 log units) below, and the stated range covers the measured number.
By their numbers in this assay, from the lowest: compound 3; then compound 1; then compounds 2 and 4 (each within the scatter of the next).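

In this assay, a 5.0-fold higher number from compound 1 to compound 4 (0.70 log units; beyond the scatter) gives the first measured read on the aromatic carbon that holds 4-acetylpiperazin-1-yl in compound 1. The number at this position therefore responds to the group it carries, and the step is beyond the scatter. Nothing available bears on the cause of this change.

As far as these compounds go, it remains open whether the step follows from the loss of the ring or of its acetyl group. An unsubstituted piperazine or a morpholine on this carbon would separate the two.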